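The compounds below may be only part of what the source reports. "The series", "measured", "known", "first", "only" and "open" are said of these compounds alone.

The three measured compounds share one core. Compound 1 `Cc1cc(NC(=O)Cn2nnc(-c3ccccc3)n2)n(C(C)C)n1` gives in an assay on HEK293 cells for activation of Kir3.1/Kir3.2 (Homo sapiens), read by thallium flux (on this read-out higher numbers stand for larger maximal responses and lower numbers for smaller maximal responses), 107%. Compound 2 `Cc1cc(NC(=O)Cn2nnc(-c3ccccc3)n2)n(Cc2ccccc2)n1` gives in this assay 74%. Within the data shown here, the one step between compounds that differ in a single place, a number 33 percentage points lower from compound 1 to compound 2 (beyond the scatter), follows benzyl in place of isopropyl on an aromatic nitrogen. Compound 3 `Cc1cc(NC(=O)Cn2nnc(-c3cccc(Cl)c3)n2)n(C2CCCCC2)n1` gives in this assay 89%, the second highest of the three numbers: it lies beyond the scatter below compound 1 and beyond the scatter above compound 2.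

Compound 4 `Cc1cc(NC(=O)Cn2nnc(-c3cccc(C(F)(F)F)c3)n2)n(C2CCCCC2)n1` has not yet been measured in this assay. It differs from compound 3 in this way: trifluoromethyl in place of chloro on an aromatic carbon. Cut one bond further out, the difference reads 3-chlorophenyl to 3-(trifluoromethyl)phenyl. Among the measured compounds shown here, no measured step touches that six-membered aromatic ring of carbon only; the only measured step concerns the aromatic nitrogen and so gives no direct guidance. The expected step of a number 4 percentage points lower from compound 3 to compound 4 (within the scatter) is therefore none beyond the scatter. Compound 4 is estimated at 85% in this assay, within 65% to 105%.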

Compound 4, largest response reached (Emax), in percent of the reference or control that the assay uses: 86%
Compound 4: middle estimate off by 1 percentage points, on the low side; the measured number falls inside the stated range.
By their numbers in this assay, from the lowest: compound 2; then compounds 4 and 3 (each within the scatter of the next); then compound 1.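

In this assay, trifluoromethyl in place of chloro on an aromatic carbon, with the rest of the molecule unchanged, gives a number 3 percentage points lower from compound 3 to compound 4 (within the scatter) and so no change that can be told from the scatter. Among these compounds, this is the first measured step on the six-membered aromatic ring of carbon only, and it shows that at this place a group of four heavy atoms can stand in for a single chlorine while the maximal response stays within the scatter. No measurement shown here explains why the two groups read alike.

On these data alone, whether an amine, a methoxy group or a carboxylic acid at this same place would also leave the response unchanged remains open. Also open, as far as these compounds go, is whether the change from chloro to trifluoromethyl would read the same with the isopropyl group of compound 1 on the aromatic nitrogen.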